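Trimming the Substituent on the Amide-Type Nitrogen to Hydroxy

A few compounds are considered here, and "the series" means these few. Any claim that something is new, unique, unknown or untested is made for them only; others in the source may bear on it.

Three measured compounds share one core and differ only in the group carried on an amide-type nitrogen. Compound 1 `COc1cc(NC(C)CCCNC(=O)NCCO)c2ncccc2c1` gives 25000 nM in a functional assay on MCF7 cells (Homo sapiens); on this read-out lower numbers stand for stronger inhibition and higher numbers for weaker inhibition. Compound 2 `COc1cc(NC(C)CCCNC(=O)NCCCCCO)c2ncccc2c1` gives 44000 nM in this assay, and the step of a 1.8-fold higher number from compound 1 to compound 2 (0.25 log units; within the scatter) stays within the scatter. Compound 3 `COc1cc(NC(C)CCCNC(=O)NC(CO)(CO)CO)c2ncccc2c1` gives 24000 nM in this assay, the lowest of the three numbers shown, yet both its nearest neighbour compound 1 and its furthest neighbour compound 2 sit within the scatter of it, as the steps of a 1.0-fold lower number from compound 1 to compound 3 (0.02 log units; within the scatter) and a 1.8-fold lower number from compound 2 to compound 3 (0.26 log units; within the scatter) show. Compound 4 `COc1cc(NC(C)CCCNC(=O)NO)c2ncccc2c1` has not yet been measured in this assay. Its difference from compound 3 is hydroxy in place of 2-hydroxy-1,1-bis(hydroxymethyl)ethyl on an amide-type nitrogen. Among the compounds with values here, the two measured steps that reach compound 3 each swapped one hydroxy-bearing group for another on that same nitrogen without moving the number beyond the scatter, so the smaller hydroxy entering here is expected to give no step beyond the scatter either, although no measured step removed this much. Compound 4 is therefore expected to give 25000 nM in this assay, in a range from 8000 nM to 75000 nM, an expected step of a 1.0-fold higher number from compound 3 to compound 4 (0.02 log units; within the scatter).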

Compound 4, half-maximal inhibitory concentration: 44000 nM
The estimate for compound 4 lay 1.8-fold (0.25 log units) below the measured number; low and high end bracket the measured number.
By their numbers in this assay, from the lowest: compounds 3, 1, 2 and 4 (each within the scatter of the next).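

Cutting the group on the amide-type nitrogen down to hydroxy, far smaller than 2-hydroxy-1,1-bis(hydroxymethyl)ethyl, still leaves the number in this assay within the scatter (a 1.8-fold higher number from compound 3 to compound 4 (0.26 log units; within the scatter)). The same holds against the other two groups (a 1.8-fold higher number from compound 1 to compound 4 (0.25 log units; within the scatter); no change at the digits printed from compound 2 to compound 4 (within the scatter)), so hydroxy, 2-hydroxyethyl, 5-hydroxypentyl and 2-hydroxy-1,1-bis(hydroxymethyl)ethyl on this nitrogen are not told apart by this read-out. No supporting measurement bears on this result, and it rests on the numbers alone.

Every group shown carries hydroxy, so it remains open whether a plain ethyl chain, an amine or a carboxylic acid on this nitrogen would give a step beyond the scatter. Changes elsewhere on the shared core also remain open.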